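The source may hold more compounds than are shown below. What is called first, only, known or untested is meant among the compounds shown, and "the series" means these compounds.

Measured compounds:
- compound 1 `CCOC(=O)CNC(=O)NCc1ccc(C(=O)N2CCCCc3ccccc32)cc1C`: 140 nM
- compound 2 `Cc1cc(C(=O)N2CCCCc3ccccc32)ccc1CNC(=O)NCC(N)=O`: 210 nM

In a functional assay on HEK293 cells for agonist activity at Vasopressin V2 receptor (Homo sapiens), read by a luciferase reporter and cAMP accumulation (a higher number here means that more compound is needed for the effect, a lower number that less compound is needed), compound 2 gives the higher of the two numbers, though its step from compound 1 is small: a 1.5-fold higher number from compound 1 to compound 2 (0.18 log units; within the scatter). Compound 3 `CCN(CC)C(=O)[C@@H]1CCCN1C(=O)NCc1ccc(C(=O)N2CCCCc3ccccc32)cc1C` is the next member, carrying (2-(diethylcarbamoyl)pyrrolidin-1-yl in place of (carbamoylmethyl)amino on a carbonyl carbon). Going by the values given here, the only measured step, the exchange of ethoxy for amino on a carbonyl carbon between compound 1 and compound 2, touched a far smaller part of the molecule and stayed within the scatter, so it offers little guidance for so large a replacement; nothing measured speaks directly to the entering group. With the shared core unchanged, compound 3 is therefore expected to land close to compound 2, with no confident direction, as a 1.4-fold lower number from compound 2 to compound 3 (0.15 log units; within the scatter). The estimate for compound 3 is 150 nM, within a wide range from 35 nM to 650 nM.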

Compound 3, half-maximal effective concentration: 350 nM
Estimate against measurement, compound 3: 2.3-fold (0.37 log units) below, and the stated range covers the measured number.
By their numbers in this assay, from the lowest: compounds 1, 2 and 3 (each within the scatter of the next, the first and the last beyond it).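

In this assay, 2-(diethylcarbamoyl)pyrrolidin-1-yl in place of (carbamoylmethyl)amino on the carbonyl carbon gives a 1.7-fold higher number from compound 2 to compound 3 (0.22 log units; within the scatter), so this position accepts a much larger group, with a five-membered ring, a defined stereocentre and no hydrogen-bond donors, without a change that stands clear of the scatter. Set against the ((ethoxycarbonyl)methyl)amino group, the same entering group gives a 2.5-fold higher number from compound 1 to compound 3 (0.40 log units; beyond the scatter), a modest step but the only one so far to pass beyond the scatter. No available evidence accounts for this step.

Going by these compounds, the ring, the diethylcarbamoyl group and the stereocentre enter together, so the share of each in the step remains open. Also open, on these data alone, is how a plain pyrrolidin-1-yl, or a pyrrolidine bearing a carboxylic acid in place of the diethylcarbamoyl group, would read in this assay.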